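Swapping the amide aryl group on a shared core

A few compounds are considered here, and "the series" means these few. Any claim that something is new, unique, unknown or untested is made for them only; others in the source may bear on it.

Among the measured compounds shown here, compound 2 `O=C(Nc1cccc(-c2oc3cc(-c4ccc(F)cc4)ccc3c(=O)c2O)c1)c1cccc(F)c1` is one of only two compounds measured in a functional assay on GTL 16 cells for antiproliferative activity against GTL 16 cell line (Homo sapiens), read by CCK-8 assay, with a stated time of 72 h; on this read-out lower numbers stand for stronger inhibition and higher numbers for weaker inhibition. In this assay compound 2 gives 15800 nM, the higher of the two numbers, and its nearest companion is compound 1 `Cc1ccc(C(=O)Nc2cccc(-c3oc4cc(-c5ccc(F)cc5)ccc4c(=O)c3O)c2)cc1`. In this assay compound 1 gives 12900 nM. For the measured compounds named here, the single measured step, a 1.2-fold higher number from compound 1 to compound 2 (0.09 log units; within the scatter), lies within the scatter, so the two compounds cannot be separated on this read-out.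

Compound 3 `Cc1cc(C)cc(C(=O)Nc2cccc(-c3oc4cc(-c5ccc(F)cc5)ccc4c(=O)c3O)c2)c1` has not yet been measured. It differs from compound 2 in one place: 3,5-dimethylphenyl in place of 3-fluorophenyl on a carbonyl carbon. Going by the values given here, the only measured step that bears on this change, a 1.2-fold higher number from compound 1 to compound 2 (0.09 log units; within the scatter), likewise exchanged one aryl group for another on the same carbonyl carbon and stayed within the scatter. Among the compounds with values here, there is no measured step that moved this read-out beyond the scatter, and no second example of the dimethyl-bearing group. On that basis no step beyond the scatter is expected for compound 3, and the expected step reads a 1.2-fold lower number from compound 2 to compound 3 (0.08 log units; within the scatter). The estimate for compound 3 in this assay is 13000 nM, with an expected range from 6000 nM to 30000 nM.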

Compound 3, half-maximal inhibitory concentration: 13500 nM
The estimate for compound 3 lay 1.0-fold (0.02 log units) below the measured number; the range from low to high includes it.
By their numbers in this assay, from the lowest: compounds 1, 3 and 2 (each within the scatter of the next).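

In this assay, 3,5-dimethylphenyl in place of 3-fluorophenyl on the carbonyl carbon gives a 1.2-fold lower number from compound 2 to compound 3 (0.07 log units; within the scatter), and 3,5-dimethylphenyl in place of 4-methylphenyl on that carbon gives a 1.0-fold higher number from compound 1 to compound 3 (0.02 log units; within the scatter). Among the compounds shown here, the earlier pair offered only a single exchange at this position, whereas three phenyl-based groups now stand there, with fluorine or with one or two methyl groups, and every pair among them remains within the scatter, so this read-out does not separate any of the three. Nothing available offers an explanation for this lack of separation, as no supporting measurement accompanies these numbers.

All three groups on this carbonyl carbon are aromatic carbon rings with no hydrogen-bond donors or acceptors, so the compounds shown leave open whether an amine, a carboxylic acid or a longer alkyl chain at this position would produce a step beyond the scatter. The rest of the shared core is the same in all three compounds, so they also say nothing about how changes elsewhere in the structure would affect the number.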